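Cytotoxicity notes on a thiopyrimidinone series

This account rests on a few compounds, and the source may have more. Where it says the series, first, only, none or still open, it means among the compounds named here.

In an ADME assay on MT4 cells (Homo sapiens) for cytotoxicity, read by MTT assay (a lower number here means that less compound is tolerated, a higher number that more compound is tolerated), compound 1 `CCc1c(Cc2c(Cl)cccc2Cl)nc(SCC(=O)c2ccc(F)cc2)[nH]c1=O` reaches only a limit, > 55000 nM (the limit of > 55000 nM in this assay, at which 1 of the 3 values shown sits). Compound 2 `CC(C)c1c(Cc2c(Cl)cccc2Cl)nc(SCC(=O)c2ccc(F)cc2)[nH]c1=O` carries methyl in place of hydrogen on a saturated chain carbon bound to an aromatic carbon and a saturated chain carbon and likewise gives a limit, > 54000 nM (the limit of > 54000 nM in this assay, at which 1 of the 3 values shown sits). The step that the two limits leave unreadable from compound 1 to compound 2 therefore cannot be sized. Compound 3 `Cc1c(Cc2c(F)cccc2Cl)nc(SCC(=O)c2ccccc2)[nH]c1=O` also stops at a limit in this assay, > 12000 nM (the limit of > 12000 nM in this assay, at which 1 of the 3 values shown sits); the difference between the cores of compound 3 and compound 1 is not broken down here. Compound 4 `CCc1c(Cc2c(F)cccc2Cl)nc(SCC(=O)c2ccccc2)[nH]c1=O` differs from compound 3 by methyl in place of hydrogen on a saturated chain carbon bound to an aromatic carbon, the same kind of change as from compound 1 to compound 2, though there the place was bound to an aromatic carbon and a saturated chain carbon. Going by the values given here, since every value so far is a limit, compound 4 is expected to tolerate a similar amount, with the step that the limit leaves unreadable from compound 3 to compound 4 estimated from the limits of compound 1 and compound 2. For compound 4 a value near 50000 nM is expected, most likely again reported as a limit.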

Compound 4, half-maximal cytotoxic concentration: > 12000 nM
Compound 4 ended at the assay's limit; the forecaster's own chance of this, stated with the estimate: 85%; the middle value is on the limit's open side.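

Going by these compounds alone, compound 4 gives > 12000 nM, a limit, and compound 3 also stops at a limit, so no step between them can be read. The compounds shown leave open where any half-maximal cytotoxic concentration actually lies, and whether methyl in place of hydrogen shifts it.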